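The source may hold more compounds than are shown below. What is called first, only, known or untested is meant among the compounds shown, and "the series" means these compounds.

Compound 3, `Cc1noc(C)c1-c1sc(N)c(C(=O)c2ccc(Cl)cc2)c1CC(C)(C)C`, stands in an assay on CHO cells for displacement of a labelled ligand from adenosine receptor A1 (Homo sapiens), read by scintillation counting, tested at 10 uM (a lower number here means less inhibition, a higher number more inhibition at the concentration tested (going by the name of the read-out)), at 1%. Two other compounds share its core and differ only in the group on the aromatic carbon of the five-membered ring. Compound 1, `Cc1ccccc1-c1sc(N)c(C(=O)c2ccc(Cl)cc2)c1CC(C)(C)C`, gives 1% in this assay. Compound 2, `CC(C)(C)Cc1c(Br)sc(N)c1C(=O)c1ccc(Cl)cc1`, gives 1% in this assay. The three steps among them show no movement: no change at the digits printed from compound 1 to compound 2 (within the scatter), no change at the digits printed from compound 1 to compound 3 (within the scatter) and no change at the digits printed from compound 2 to compound 3 (within the scatter). Compound 3 is thus level with compound 1 and compound 2 at the digits printed.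

Compound 4, `CC(C)(C)Cc1c(-c2ccsc2)sc(N)c1C(=O)c1ccc(Cl)cc1`, is the next compound to be measured. Its difference from compound 3 is thiophen-3-yl in place of 3,5-dimethyl-1,2-oxazol-4-yl on an aromatic carbon. The three measured steps all change the group at this same aromatic carbon, and all of them stayed within the scatter, so a further exchange of the group there is expected to give no change beyond the scatter, that is a number 1 percentage points higher from compound 3 to compound 4 (within the scatter). Compound 4 is therefore estimated to give 2% in this assay, within a range from -6% to 12%.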

Compound 4, a percentage reported as inhibition, at one concentration (the size of the read-out at that concentration, not a potency): 2%
For compound 4 middle estimate and measured number coincide at the digits printed; measured number inside the range.
By their numbers in this assay, from the lowest: compounds 1, 2, 3 and 4 (each within the scatter of the next).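

In this assay the exchange for thiophen-3-yl gives a number 1 percentage points higher from compound 3 to compound 4 (within the scatter) and a number 1 percentage points higher from compound 2 to compound 4 (within the scatter) as well as a number 1 percentage points higher from compound 1 to compound 4 (within the scatter) and so adds a fourth group to the set at this aromatic carbon without moving the read-out beyond the scatter. The earlier compounds had not shown this for a five-membered aromatic ring with sulfur as its only hetero atom and without methyl groups, so the flat picture at this position now covers that ring as well. Nothing available here bears on why the read-out stays flat at this position.

As far as these compounds go, whether an aminomethyl group or a carboxylic acid at this carbon would give a different number remains open. So does the effect of changing the neopentyl, amino or (4-chlorophenyl)carbonyl groups, which are the same in all four compounds.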